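Shortening the Chain on the Adenosine-Like Core

The source may report more compounds than this note shows. Statements on the series, on what has been measured and on what is new or still open speak of the compounds shown alone.

The compounds share the core of compound 1 `Nc1ncnc2c1ncn2[C@@H]1O[C@H](COC(=O)OCc2ccccc2)[C@@H](O)[C@H]1O`, a nucleoside whose sugar carries a benzyl carbonate; in an assay on COS-7 cells for inhibition of sodium/nucleoside cotransporter 2 (Homo sapiens), read by scintillation counting, in the presence of a further agent that is not named here (a higher number here means a weaker inhibitor, a lower number a stronger inhibitor), compound 1 reaches only the limit > 100000 nM, which is a bound of the assay and not a number, and the limit of > 100000 nM in this assay, at which 1 of the 3 values shown sits, records this. Compound 2 `Nc1ncnc2c1nc(NCCCc1ccccc1)n2[C@@H]1O[C@H](CO)[C@@H](O)[C@H]1O` carries a 3-phenylpropyl amine on the core and in this assay gives 536000 nM, the highest of the two measured numbers. Compound 3 `Nc1ncnc2c1nc(NCc1ccc(-c3ccccc3)cc1)n2[C@@H]1O[C@H](CO)[C@@H](O)[C@H]1O` carries a biphenylmethyl amine instead and gives 640 nM, a far lower number, so the difference between these two lies well beyond the scatter.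

Compound 4 `COc1cccc(CNc2nc3c(N)ncnc3n2[C@@H]2O[C@H](CO)[C@@H](O)[C@H]2O)c1` is not yet measured. It differs from compound 2 in one place: 3-methoxyphenyl in place of phenethyl on a saturated chain carbon bound to a nitrogen on an aromatic ring. The change thus trims the chain between the ring nitrogen and the aromatic ring and adds a methoxy group.

Compound 3, with its value of 640 nM, shows that a shorter link to an aromatic group can go with a much lower number. The step from compound 2 to compound 4 is therefore expected to lower the number by a good margin, a 27-fold lower number from compound 2 to compound 4 (1.43 log units; beyond the scatter), though not to the level of compound 3. Compound 4 is estimated at 20000 nM, within a range of 3000 nM to 200000 nM.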

Compound 4, half-maximal inhibitory concentration: 13000 nM
The estimate for compound 4 lay 1.5-fold (0.19 log units) above the measured number; measured number inside the range.
By their numbers in this assay, from the lowest: compound 3; then compound 4; then compound 2.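

Swapping 3-phenylpropyl for 3-methoxybenzyl on the shared core gives, in this assay, a 41-fold lower number from compound 2 to compound 4 (1.62 log units; beyond the scatter), so this position responds strongly to a change in the group it carries. Each of the two pieces that differ holds one six-membered aromatic ring and the same count of heavy atoms, which shows that so large a step can arise without any growth in the size of the group. The step still joins two edits in one, a shorter chain and an added methoxy, and nothing measured here explains its size.

Which edit carries the step stays open: a plain benzyl group on the same nitrogen would differ from compound 4 only by the missing methoxy, and a 3-methoxy-substituted 3-phenylpropyl group would differ from it only in chain length. Equally open, on these data alone, is whether the methoxy itself matters, which a hydroxyl group or a chlorine atom in its place would begin to test.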